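The source may report more compounds than this note shows. Statements on the series, on what has been measured and on what is new or still open speak of the compounds shown alone.

Measured so far:
compound 1, `c1ccc(-c2cn3ccnc3c(-c3ccc4ncn(C5CCCCC5)c4c3)n2)cc1`: 23.8%
compound 2, `CC(=O)c1ccc(-c2cn3ccnc3c(-c3ccc4ncn(C5CCCCC5)c4c3)n2)cc1`: 6.34%

Both numbers come from a functional assay on Hs-578T cells (Homo sapiens) for inhibition, read by sulforhodamine B assay, with a stated time of 48 h, tested at 10 uM; a lower number here means less inhibition, a higher number more inhibition at the concentration tested (going by the name of the read-out). Among the measured compounds shown here, compound 2 stands lowest of the two; the only measured step, a number 17.5 percentage points lower from compound 1 to compound 2 (beyond the scatter), separates it from compound 1 beyond the scatter.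

Compound 3, `Fc1ccccc1-c1cn2ccnc2c(-c2ccc3ncn(C4CCCCC4)c3c2)n1`, differs from compound 2 in one place: 2-fluorophenyl in place of 4-acetylphenyl on an aromatic carbon. The step from compound 1 to compound 2 bears on this change, since compound 3 also gives up the acetyl that compound 2 carries and compound 1 lacks. For the measured compounds named here, no measured pair, however, shows a fluorine entering, so that part of the change has no measured footing here. A rise back toward the number of compound 1 is therefore expected, modest in size and uncertain. The step expected in this assay is a number 13.7 percentage points higher from compound 2 to compound 3 (beyond the scatter). Compound 3 is estimated at 20%, with a range from 5% to 38%.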

Compound 3, a percentage reported as inhibition, at one concentration (the size of the read-out at that concentration, not a potency): 5.26%
Beside the measured number, compound 3's estimate is 14.7 percentage points above it; measured number inside the range.
By their numbers in this assay, from the lowest: compounds 3 and 2 (each within the scatter of the next); then compound 1.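

In this assay the change from 4-acetylphenyl to 2-fluorophenyl gives a number 1.1 percentage points lower from compound 2 to compound 3 (within the scatter) and so does not separate these two groups at this place on the shared core. The step of a number 18.5 percentage points lower from compound 1 to compound 3 (beyond the scatter) adds what the acetyl step alone could not show: a low number here does not depend on the acetyl, since a fluoro group on the phenyl ring also goes with a number below that of the unsubstituted phenyl in compound 1. No measurement shown explains this shared drop.

As far as these compounds go, with only these two substituted phenyl groups, it remains open whether fluoro elsewhere on the ring would behave the same way. From the compounds shown here alone, it is also open whether an amine or a carboxylic acid on that ring would stay near compound 1 or fall with compound 2 and compound 3.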